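This account rests on a few compounds, and the source may have more. Where it says the series, first, only, none or still open, it means among the compounds named here.

Within the data shown here, compound 2 `Oc1ccccc1-c1cc(-c2ccccc2C(F)(F)F)cc(-c2ccccc2O)n1` is the one compound here with a numerical result: in a functional assay on DU-145 cells (Homo sapiens) for inhibition (on this read-out higher numbers stand for weaker inhibition and lower numbers for stronger inhibition), compound 2 gives 4770 nM. Compound 1 `Oc1cccc(-c2cc(-c3ccc(F)cc3)cc(-c3ccccc3O)n2)c1` reaches only a limit of the assay, giving > 50000 nM in this assay. That limit is the point noted in the limit of > 50000 nM in this assay, at which 1 of the 2 values shown sits; the data do not say how far beyond it compound 1 lies, so compound 1 and compound 2 cannot be compared as two numbers.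

Compound 3 `Oc1cccc(-c2cc(-c3ccccc3C(F)(F)F)cc(-c3ccccc3O)n2)c1` is built from the same atoms as compound 2, joined differently: 3-hydroxyphenyl in place of 2-hydroxyphenyl on an aromatic carbon. Among the measured compounds shown here, no measured pair isolates this change, so its size must be guessed. Compound 1 also carries a 3-hydroxyphenyl group, yet compound 1 differs from compound 2 in a second place as well, so its limit is only a loose hint. The expectation is a moderate loss of inhibition, a step of a 3.1-fold higher number from compound 2 to compound 3 (0.50 log units; beyond the scatter), giving compound 3 an estimated 15000 nM in this assay, within a range from 4000 nM to 50000 nM.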

Compound 3, half-maximal inhibitory concentration: 7250 nM
Compound 3: middle estimate off by 2.1-fold (0.32 log units), on the high side, and the stated range covers the measured number.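

On the aromatic carbon next to the ring nitrogen, 3-hydroxyphenyl in place of 2-hydroxyphenyl gives a 1.5-fold higher number from compound 2 to compound 3 (0.18 log units; within the scatter) in this assay, so this swap makes no measurable difference here. The other change, 2-(trifluoromethyl)phenyl in place of 4-fluorophenyl on an aromatic carbon, has a clearer effect, with an at least 6.8-fold lower number from compound 1 to compound 3 (0.83 log units; beyond the scatter). That size is only a minimum, since the value of compound 1 is a limit and not a number: the limit of > 50000 nM in this assay, at which 1 of the 3 values shown sits.

The compounds shown leave open whether the hydroxyl group is needed at this position at all, as a plain phenyl ring would test, and how a 4-hydroxyphenyl group would read there. They also do not tell how an amine or a carboxylic acid on that ring would change the result.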